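Chromone vinyl sulfoxides: ether to ester at the phenolic oxygen

The source may report more compounds than this note shows. Statements on the series, on what has been measured and on what is new or still open speak of the compounds shown alone.

Three compounds share the core seen in compound 1 `CCCCCOc1ccc2oc(/C=C/[S+](C)[O-])cc(=O)c2c1`, and all three were run in a functional assay on DLD-1 cells (Homo sapiens) for cytotoxicity, with a stated time of 48 h; a higher number here means a weaker inhibitor, a lower number a stronger inhibitor. Compound 1 gives 6600 nM in this assay. Compound 2 `Cc1cccc2c(=O)cc(/C=C/[S+](C)[O-])oc12` gives 6800 nM in this assay, and compound 3 `Cc1c(/C=C/[S+](C)[O-])oc2ccccc2c1=O` gives 7200 nM. Compound 1 thus carries the lowest of the three numbers, but compound 2 and compound 3 both sit within the usual scatter of it, so the three are not separated by these data and no order among them can be read.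

The next compound, compound 4 `CCC(=O)Oc1ccc2oc(/C=C/[S+](C)[O-])cc(=O)c2c1`, is not yet measured in this assay. It differs from compound 1 in one place: propanoyl in place of pentyl on an oxygen on an aromatic ring. Cut one bond further out, the change reads pentyloxy to propanoyloxy.

For the measured compounds named here, no pair of measured compounds differing in one place is available, so the size of this step has no precedent in the set. The three measured compounds cluster tightly, and nothing in them argues for a large move in either direction. The step from compound 1 to compound 4 is therefore expected to be small, a 1.2-fold higher number from compound 1 to compound 4 (0.08 log units; within the scatter), and quite possibly none beyond the scatter. Compound 4 is estimated at 8000 nM in this assay, within a range of 3500 nM to 18000 nM.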

Compound 4, half-maximal inhibitory concentration: 9000 nM
The estimate for compound 4 lay 1.1-fold (0.05 log units) below the measured number; the measured number falls inside the stated range.
By their numbers in this assay, from the lowest: compounds 1, 2, 3 and 4 (each within the scatter of the next).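

In this assay, for the compounds shown here, the first pair differing in one place gives a 1.4-fold higher number from compound 1 to compound 4 (0.13 log units; within the scatter), so propanoyl in place of pentyl on an oxygen on an aromatic ring does not separate the two compounds. The change from ether to ester at this oxygen brings in a double bond outside aromatic rings and a hydrogen-bond acceptor, and swaps a chain of 5 carbons for one of 3, yet none of this appears as a step beyond the scatter. This position therefore accepts at least this one exchange of pentyloxy for propanoyloxy with no readable shift in the cytotoxicity number.

This single step cannot show whether the position stays as flat across other groups on the same oxygen, such as a free hydroxyl, a longer acyl chain, a benzoyl group or a chain ending in an amine or a carboxylic acid. It also leaves open whether the ester survives intact over the assay period, so the number for compound 4 may or may not reflect the ester itself.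

No measurement of any property bears on this result.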